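This account rests on a few compounds, and the source may have more. Where it says the series, first, only, none or still open, it means among the compounds named here.

Measured compounds:
Compound 1 `C=CCNC(=O)n1c(-c2ccc(OC)cc2)cc(=O)c2c(OC)cc(OC)cc21`: in an ADME assay on BJ cells (Homo sapiens) for antiproliferative activity, with a stated time of 72 h (a higher number here means that more compound is needed for the effect, a lower number that less compound is needed), compound 1 gives 74000 nM.
Compound 2 `COc1ccc(-c2cc(=O)c3c(OC)cc(OC)cc3n2S(=O)(=O)c2ccc(C=O)cc2)cc1`: in this assay compound 2 gives > 34400 nM, which is a limit of the assay and not a number.
Compound 3 `COc1ccc(-c2cc(=O)c3c(OC)cc(OC)cc3n2S(=O)(=O)c2ccc(Br)cc2)cc1`: in this assay compound 3 gives > 86200 nM, again a limit of the assay and not a number.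

Compound 3 thus stands at the limit of > 86200 nM in this assay, at which 1 of the 3 values shown sits, with no number of its own; of the three measured compounds only compound 1 has a number. The step of an at least 1.1-fold higher number from compound 1 to compound 3 (0.06 log units; that floor lies within the scatter) gives only a floor. The steps a step that the limit leaves unreadable from compound 1 to compound 2 and a step that the two limits leave unreadable from compound 2 to compound 3 cannot be sized.

Compound 4 `COc1ccc(-c2cc(=O)c3c(OC)cc(OC)cc3n2S(=O)(=O)c2ccc(C)cc2)cc1` differs from compound 3 by methyl in place of bromo on an aromatic carbon. Among the compounds with values here, no measured step bears on an exchange of bromo for methyl at this position; the one readable step, from compound 1 to compound 3, concerns the group on the aromatic nitrogen, which compound 3 and compound 4 share. Compound 2 and compound 3 both carry an arylsulfonyl group and neither gives a number. The step that the limit leaves unreadable from compound 3 to compound 4 is therefore expected to be none beyond the scatter. Compound 4 is estimated at 90000 nM, in a range of 35000 nM to 250000 nM, and a limit rather than a number is the more likely outcome.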

Compound 4, half-maximal effective concentration: > 44800 nM
Compound 4: a limit, no number; the forecaster's own chance of this, stated with the estimate: 70%; the middle value is on the limit's open side.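

In this assay compound 4 gives > 44800 nM, a limit of the assay and not a number, so its steps from compound 1, compound 2 and compound 3 cannot be read. The compounds shown leave open whether formyl, bromo and methyl differ at all in the arylsulfonyl group.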